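Chain length on a shared amino-oxolane core

The compounds below may be only part of what the source reports. "The series", "measured", "known", "first", "only" and "open" are said of these compounds alone.

Measured compounds:
compound 1 `CCCCCCCCCCCCNC[C@@H]1OC[C@H](N)[C@@H]1O` gives 850 nM
compound 2 `CCCCCCCNC[C@@H]1OC[C@H](N)[C@H]1O` gives > 128000 nM
compound 3 `CCCCCCCCCCNC[C@@H]1OC[C@H](N)[C@H]1O` gives > 128000 nM

All three were tested in a functional assay on PC-3 cells (Homo sapiens) for antiproliferative activity, read by MTT assay, with a stated time of 72 h; on this read-out lower numbers stand for stronger inhibition and higher numbers for weaker inhibition. Going by the values given here, compound 1 gives the only number in this assay, 850 nM. The value of compound 2 is a limit of this assay, not a number. The value of compound 3 is likewise a limit. How the core of compound 1 differs from that of compound 3 is not broken down here.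

The step that the two limits leave unreadable from compound 3 to compound 2 is hydrogen in place of propyl on a saturated chain carbon, seven bonds along the chain from an amine nitrogen. The same kind of change, (hydrogen in place of propyl on a saturated chain carbon, nine bonds along the chain from an amine nitrogen), leads to compound 4 `CCCCCCCCCNC[C@@H]1OC[C@H](N)[C@@H]1O`, though here the place is nine bonds along the chain from the amine nitrogen rather than seven. Among the compounds with values here, because the limit of > 128000 nM in this assay, at which 2 of the 3 values shown sit, covers both ends of the measured step, its size cannot be read, so it gives no guide to the step from compound 1.

Compound 4 is expected to lose activity in this assay, with an 18-fold higher number from compound 1 to compound 4 (1.25 log units; beyond the scatter) a rough estimate only. The estimate for compound 4 is 15000 nM, with a real chance that only a limit results.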

Compound 4, half-maximal inhibitory concentration: 2030 nM
Compound 4: the middle estimate sits 7.4-fold (0.87 log units) above what was measured; measured number inside the range.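

On the core of compound 1, hydrogen in place of propyl, nine bonds along the chain from the amine nitrogen, gives a 2.4-fold higher number from compound 1 to compound 4 (0.38 log units; beyond the scatter) in this assay. On the core shared by compound 2 and compound 3, the same kind of change, seven bonds along the chain from the amine nitrogen, cannot be read, because both compounds sit at a limit and not at a number: the limit of > 128000 nM in this assay, at which 2 of the 4 values shown sit. The change is therefore readable on one core only, so these data show neither that its modest size carries over to the other core nor that it fails to, and the place of the change also differs between the two cores.

Still open, going by these compounds, is how a longer chain would read on the core of compound 1 in this assay, and whether any chain length brings the core of compound 3 to a number. Also open, on these data alone, is whether a chain bearing an amine or a carboxylic acid would hold the activity of compound 4.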